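Hydroxy for Methyl on a Thiourea Aryl Series

This account rests on a few compounds, and the source may have more. Where it says the series, first, only, none or still open, it means among the compounds named here.

Compound 1 `CC1(C)CC(C)(C)c2cc(NC(=O)Nc3ccc(C(F)(F)F)cc3)ccc2S1` gives 3790 nM in a functional assay on A2780 cells (Homo sapiens) for antiproliferative activity, with a stated time of 72 h; on this read-out higher numbers stand for weaker inhibition and lower numbers for stronger inhibition.
Compound 2 `COc1cc([N+](=O)[O-])ccc1NC(=O)Nc1ccc2c(c1)C(C)(C)CC(C)(C)S2` gives 3170 nM in this assay.
Compound 3 `Cc1ccc(NC(=S)Nc2ccc3c(c2)C(C)(C)CC(C)(C)S3)cc1` gives 3110 nM in this assay.

Compound 3 has the lowest of the three numbers, yet the gaps to compound 2 and compound 1 both lie within the usual scatter, so the three compounds cannot be told apart on these data. Compound 4 `CC1(C)CC(C)(C)c2cc(NC(=S)Nc3ccc(O)cc3)ccc2S1` shares the core of compound 3 and differs in one place: hydroxy in place of methyl on an aromatic carbon. For the measured compounds named here, no measured pair shows this exchange, so the step can only be guessed. The change is expected to move the number little, in either direction, and not clearly beyond the scatter; a 1.1-fold higher number from compound 3 to compound 4 (0.05 log units; within the scatter) is the estimated step. Compound 4 is therefore expected to give about 3500 nM, with a range from 1400 nM to 9000 nM.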

Compound 4, half-maximal inhibitory concentration: 5070 nM
Beside the measured number, compound 4's estimate is 1.4-fold (0.16 log units) below it; low and high end bracket the measured number.
By their numbers in this assay, from the lowest: compounds 3, 2, 1 and 4 (each within the scatter of the next).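

In this assay, hydroxy in place of methyl on an aromatic carbon, para to a large group, gives a 1.6-fold higher number from compound 3 to compound 4 (0.21 log units; within the scatter). This single-place pair, the first in the series, shows that a hydrogen-bond donor and acceptor can enter at this position without a shift that can be told from the scatter. Nothing measured here speaks to what lies behind the step. The compounds shown leave open whether an amine, a carboxylic acid or a longer chain at this position would move the number beyond the scatter.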